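This account rests on a few compounds, and the source may have more. Where it says the series, first, only, none or still open, it means among the compounds named here.

Measured compounds, all in an assay on HeLa cells for displacement of a labelled ligand from adenosine receptor A3 (Homo sapiens), read by scintillation counting, with a stated time of 180 min, tested at 10 uM; a lower number here means less inhibition, a higher number more inhibition at the concentration tested (going by the name of the read-out):

compound 1 `COc1cccc2cc(C(=O)NCC(=O)O)c(=O)oc12` gives 15%
compound 2 `O=C(O)CNC(=O)c1cc2ccccc2oc1=O` gives 0%
compound 3 `COc1cccc2cc(C(=O)NC3CCCCC3)c(=N)oc12` gives 16%

Compound 1 stands second highest of the three numbers in this assay. The nearest number is that of compound 3, which lies within the scatter of compound 1, so the two read as the same. Going by the values given here, the furthest is compound 2, and that pair is the one measured step in the set: a number 15 percentage points lower from compound 1 to compound 2 (beyond the scatter), for hydrogen in place of methoxy on an aromatic carbon. Among the compounds with values here, compound 3 differs from compound 1 in more than one place, and no single step connects them.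

Compound 4 `COc1cccc2cc(C(=O)NCC(O)CO)c(=O)oc12` is the next member to be measured. Relative to compound 1 the change is 1,2-dihydroxyethyl in place of carboxy on a saturated chain carbon bound to an amide-type nitrogen. Within the data shown here, the only measured step concerns the methoxy on the aromatic ring and leaves the amide side untouched, so it does not bear on this change, and nothing in the set isolates a change at the saturated chain carbon. Among the measured compounds shown here, with no step pointing either way, the expectation is a move within the scatter: a number 3 percentage points lower from compound 1 to compound 4 (within the scatter). The estimate for compound 4 in this assay is 12%, with a range of 0% to 30%.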

Compound 4, a percentage reported as inhibition, at one concentration (the size of the read-out at that concentration, not a potency): 1%
For compound 4 the middle estimate is 11 percentage points above the measured one, within the range that was stated.
By their numbers in this assay, from the lowest: compounds 2 and 4 (each within the scatter of the next); then compounds 1 and 3 (each within the scatter of the next).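

In this assay, 1,2-dihydroxyethyl in place of carboxy on a saturated chain carbon bound to an amide-type nitrogen gives a number 14 percentage points lower from compound 1 to compound 4 (beyond the scatter), so the amide side of the series also moves the read-out, which the earlier step could not show. Compound 1 now has a step at each of two separate places, this one and the hydrogen in place of methoxy on an aromatic carbon with a number 15 percentage points lower from compound 1 to compound 2 (beyond the scatter), and both changes read lower. No measured evidence bears on why the number falls with this exchange.

Still open, from the compounds shown here alone, is whether the fall tracks the loss of the carboxy or the presence of 1,2-dihydroxyethyl itself, a question that a simple 2-hydroxyethyl, a methyl ester of the acid or a primary amine at the same place would help to separate. The numbers come from one concentration and give no potency, and whether the methoxy step would hold with 1,2-dihydroxyethyl on the amide side also remains unsettled.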